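Acetyl in place of trifluoromethyl on a shared core

This account rests on a few compounds, and the source may have more. Where it says the series, first, only, none or still open, it means among the compounds named here.

Compound 1 `COc1ccc(-c2nc3cc(C(F)(F)F)ccc3[nH]2)c(OC)c1OC` was tested in an ADME assay on MDBK cells (Bos taurus) for cytotoxicity, read by MTT assay, with a stated time of 96 h; a higher number here means that more compound is tolerated, a lower number that less compound is tolerated. In this assay compound 1 gives only a limit, > 100000 nM. Its close relative compound 2 `COc1ccc(-c2nc3cc(C(F)(F)F)ccc3[nH]2)c(OC)c1` likewise gives only a limit in this assay, > 100000 nM. The step that the two limits leave unreadable from compound 1 to compound 2 therefore cannot be read, since the limit of > 100000 nM in this assay, at which 2 of the 3 values shown sit, caps both ends of it. A third compound, compound 3 `O=C(CN1CCCC1)Nc1ccc(-c2nc3ccccc3[nH]2)cc1`, gives a number in this assay, 70000 nM. Compound 1 thus stands at the limit of what the assay can report, and no readable step places it more finely.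

The unmeasured compound 4 `COc1ccc(-c2nc3cc(C(C)=O)ccc3[nH]2)c(OC)c1OC` differs from compound 1 by acetyl in place of trifluoromethyl on an aromatic carbon. For the measured compounds named here, no measured step covers this change, and the single step that is measured is unreadable. With nothing pointing either way, compound 4 is expected to remain close to compound 1, a step of a number no higher from compound 1 to compound 4 (the limit leaves the size open). In this assay compound 4 is therefore estimated at 100000 nM, with a range from 50000 nM to 200000 nM.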

Compound 4, half-maximal cytotoxic concentration: > 100000 nM
Compound 4 gave a limit, no number; the forecaster's own chance of this, stated with the estimate: 60%; the middle value sits exactly at the limit.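

In this assay compound 4 gives only a limit, > 100000 nM. The change from compound 1 to compound 4 therefore cannot be read as a step, because both compounds stop at the same limit: the limit of > 100000 nM in this assay, at which 3 of the 4 values shown sit. The compounds shown leave open whether acetyl or trifluoromethyl on the shared core gives the higher value in this assay.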